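This account rests on a few compounds, and the source may have more. Where it says the series, first, only, none or still open, it means among the compounds named here.

Compound 1, `COc1cc2c(Oc3ccc(NC(=O)c4cc(-c5ccccc5C)ccn4)cc3F)ccnc2cc1OCCCN1CCN(C)CC1`, gives 150 nM in a functional assay on NCI-H460 cells (Homo sapiens) for cytotoxicity, read by MTT assay, with a stated time of 72 h; on this read-out lower numbers stand for stronger inhibition and higher numbers for weaker inhibition.
Compound 2, `COc1cc2c(Oc3ccc(NC(=O)c4cc(-c5ccc(C(F)(F)F)cc5)ccn4)cc3F)ccnc2cc1OCCCN1CCN(C)CC1`, gives 160 nM.
Compound 3, `COc1cc2c(Oc3ccc(NC(=O)c4cc(-c5ccccc5C)ccn4)cc3F)ccnc2cc1OCCCN1CCCC1`, gives 420 nM.

Of the three measured compounds, compound 3 stands with the highest number in this assay. The step of a 2.8-fold higher number from compound 1 to compound 3 (0.45 log units; beyond the scatter) is beyond the scatter, and compound 2 also sits below compound 3 by a gap beyond the scatter. For the measured compounds named here, the only change between compound 1 and compound 2, the exchange of the 2-methylphenyl for the 4-(trifluoromethyl)phenyl on the pyridine carbon, gave a 1.1-fold higher number from compound 1 to compound 2 (0.03 log units; within the scatter), a step inside the scatter.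

Compound 4, `COc1cc2c(Oc3ccc(NC(=O)c4cc(-c5ccc(C(F)(F)F)cc5)ccn4)cc3F)ccnc2cc1OCCCN1CCCC1`, has not yet been measured. It differs from compound 3 in one place: 4-(trifluoromethyl)phenyl in place of 2-methylphenyl on an aromatic carbon. This is the same exchange already seen in the pair of compound 1 and compound 2, where the step of a 1.1-fold higher number from compound 1 to compound 2 (0.03 log units; within the scatter) was within the scatter. On that single precedent, the step of a 1.1-fold higher number from compound 3 to compound 4 (0.03 log units; within the scatter) is expected to stay within the scatter, with no clear direction. Compound 4 is therefore estimated to give 450 nM in this assay, with a range of 220 nM to 900 nM. The estimate rests on one measured pair only, so the range is kept wide.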

Compound 4, half-maximal inhibitory concentration: 250 nM
Compound 4: middle estimate off by 1.8-fold (0.26 log units), on the high side, within the range that was stated.
By their numbers in this assay, from the lowest: compounds 1, 2, 4 and 3 (each within the scatter of the next, the first and the last beyond it).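

In this assay, the exchange of 2-methylphenyl for 4-(trifluoromethyl)phenyl, on the aromatic carbon opposite the ring nitrogen, now also stays within the scatter with pyrrolidin-1-yl at the chain end, giving a 1.7-fold lower number from compound 3 to compound 4 (0.23 log units; within the scatter), and the two readings of this change agree within the scatter: the same change on two cores in this assay, a 1.1-fold higher number (0.03 log units; within the scatter) from compound 1 to compound 2 and a 1.7-fold lower number (0.23 log units; within the scatter) from compound 3 to compound 4, 1.8-fold (0.25 log units) apart, within the scatter of two such steps. The exchange of 4-methylpiperazin-1-yl for pyrrolidin-1-yl, which was beyond the scatter with 2-methylphenyl in place, is within the scatter with 4-(trifluoromethyl)phenyl in place, giving a 1.6-fold higher number from compound 2 to compound 4 (0.19 log units; within the scatter). The clear step seen earlier therefore did not carry over to the second core, although the two steps themselves do not differ beyond the scatter: the same change on two cores in this assay, a 2.8-fold higher number (0.45 log units; beyond the scatter) from compound 1 to compound 3 and a 1.6-fold higher number (0.19 log units; within the scatter) from compound 2 to compound 4, 1.8-fold (0.25 log units) apart, within the scatter of two such steps.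

With only two aryl groups and two amines at hand, the compounds shown leave open how a phenyl ring carrying a carboxylic acid or a primary amine would read at this aromatic carbon. They also leave open whether a morpholine at the end of the chain, or a shorter or longer chain, would stay within the scatter of these four compounds.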